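The compounds below may be only part of what the source reports. "The series", "measured", "known", "first", "only" and "open" are said of these compounds alone.

Measured so far in a physicochemical assay for lipophilicity, measured as octanol-water partition, at pH 7.4; on this read-out higher numbers stand for higher lipophilicity and lower numbers for lower lipophilicity:
compound 1 `O=C([C@H](O)CS(=O)(=O)c1ccc2cc(Cl)ccc2c1)N1CCC(N2CCOC2=O)CC1` gives 1.75
compound 2 `O=C([C@H](O)CS(=O)(=O)c1ccc2cc(Cl)ccc2c1)N1CCC(N2CCOCC2=O)CC1` gives 1.85

Compound 1 and compound 2 lie within the usual scatter of each other, so neither number can be set apart from the other. Compound 3 `O=C([C@H](O)CS(=O)(=O)c1ccc2cc(Cl)ccc2c1)N1CCC(N2NCCCC2=O)CC1` has not yet been measured. The change from compound 1 to compound 3 (a group of 7 heavy atoms (4 carbon, 2 nitrogen, 1 oxygen; one six-membered non-aromatic ring with 2 hetero atoms) in place of a group of 6 heavy atoms (3 carbon, 1 nitrogen, 2 oxygen; one five-membered non-aromatic ring with 2 hetero atoms), on a saturated ring carbon) falls on a saturated ring carbon of a six-membered non-aromatic ring with 1 nitrogen. Among the measured compounds shown here, the one measured step that bears on it (a number 0.10 log units higher from compound 1 to compound 2 (within the scatter)) also replaces 2-oxo-1,3-oxazolidin-3-yl on that carbon, there with 3-oxomorpholin-4-yl, and it stayed small. For the measured compounds named here, the group entering compound 3 carries a hydrogen-bond donor, and no measured compound shows what that does in this assay here, so the range is kept wide. The expected step (a number 0.05 log units higher from compound 1 to compound 3 (within the scatter)) is therefore none beyond the scatter. Compound 3 is expected to show an estimated value of 1.8 (range 1.4 to 2.2).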

Compound 3, distribution coefficient: 1.85
For compound 3 the middle estimate is 0.05 log units below the measured one, within the range that was stated.
By their numbers in this assay, from the lowest: compounds 1, 2 and 3 (each within the scatter of the next).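

The group entering compound 3 is the only one of the three to carry a hydrogen-bond donor, yet in this assay the swap gave a number 0.10 log units higher from compound 1 to compound 3 (within the scatter) and no change at the digits printed from compound 2 to compound 3 (within the scatter) at this saturated ring carbon. So, among these three compounds, a ring group with a hydrogen-bond donor cannot be told apart from the two ring groups without one on this read-out. No measurement here explains this result.

As far as these compounds go, all three groups are rings that carry a carbonyl and no net charge, so it remains open how far this assay would move with a carboxylic acid or an amine on the same carbon. From the compounds shown here alone, an open chain in place of the ring is equally open.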